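The compounds below may be only part of what the source reports. "The series", "measured", "known", "first", "only" and "open" are said of these compounds alone.

Measured compounds:
compound 1, `CSc1nc2ccccn2c(=N)c1S(=O)(=O)c1ccc(OC(F)(F)F)cc1`, 420 nM
compound 2, `CCNc1nc2ccccn2c(=N)c1S(=O)(=O)c1ccccc1`, 2 nM
compound 3, `CSc1nc2ccc(F)cn2c(=N)c1S(=O)(=O)c1ccccc1`, 28 nM

In an assay on HeLa cells for displacement of a labelled ligand from 5-hydroxytryptamine receptor 6 (Homo sapiens) (on this read-out lower numbers stand for stronger inhibition and higher numbers for weaker inhibition), compound 3 sits second highest of the three numbers. Its nearest neighbour is compound 2, whose value of 2 nM lies well below it, beyond the scatter; the furthest is compound 1, whose value of 420 nM lies well above it, also beyond the scatter. Compound 4, `COC(=O)c1ccc2nc(SC)c(S(=O)(=O)c3ccccc3)c(=N)n2c1`, has not yet been measured in this assay. It differs from compound 3 in one place: methoxycarbonyl in place of fluoro on an aromatic carbon. For the measured compounds named here, none of the measured pairs shares this change, so there is no step to lean on; the other two compounds differ from compound 3 in several places at once, and their values say nothing direct about a change on the fused ring. For that reason the step from compound 3 to compound 4 is expected to be modest, with no firm direction, and most likely within or only slightly beyond the scatter, a 1.4-fold higher number from compound 3 to compound 4 (0.15 log units; within the scatter). The expected value for compound 4 in this assay is 40 nM, with a range from 8 nM to 200 nM.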

Compound 4, half-maximal inhibitory concentration: 470 nM
Compound 4: middle estimate off by 12-fold (1.07 log units), on the low side; measured number outside the range, above it.
By their numbers in this assay, from the lowest: compound 2; then compound 3; then compounds 1 and 4 (each within the scatter of the next).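

In this assay, exchanging fluoro for methoxycarbonyl on this aromatic carbon, two atoms from the ring nitrogen, gives a 17-fold higher number from compound 3 to compound 4 (1.22 log units; beyond the scatter). For the compounds shown here, this is the first comparison that isolates a single change, and it shows that the number depends strongly on the group at this position of the fused ring system, with the larger methoxycarbonyl group giving the much weaker inhibition. Nothing available here accounts for the size of this step.

The compounds shown leave open whether a methyl group, an amine or a carboxylic acid at this carbon would give a number closer to that of compound 3 or of compound 4. They also leave open whether the same exchange would give a step of similar size on the core of compound 2.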